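The compounds below may be only part of what the source reports. "The series", "measured", "known", "first", "only" and "open" are said of these compounds alone.

Going by the values given here, in a physicochemical assay for solubility, at pH 6.8 (a higher number here means a more soluble compound, a lower number a less soluble compound), compound 2 `COc1ncc(NC(=O)Nc2cnc3cc(Cl)nn3c2N2[C@@H](C)COC[C@@H]2C)cc1Cl` gives 81000 nM, the only actual number so far. Compound 1 `COc1ccc(NC(=O)Nc2cnc3ccc(Br)cc3c2)cc1Cl` gives < 4000 nM, which is a limit and not a number. Compound 3 `C[C@H]1COC[C@H](C)N1c1c(NC(=O)Nc2ccnc(C(F)(F)F)c2)cnc2cc(Cl)nn12` keeps the core of compound 2 but carries 2-(trifluoromethyl)pyridin-4-yl in place of 5-chloro-6-methoxypyridin-3-yl on an amide-type nitrogen. Among the compounds with values here, no measured pair shows what such a swap does, so no change beyond the usual scatter is expected. The estimated step of a 1.2-fold higher number from compound 2 to compound 3 (0.09 log units; within the scatter) is correspondingly small. Compound 3 is expected to read about 100000 nM, within an estimated range of 30000 nM to 300000 nM.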

Compound 3, solubility: 266000 nM
Compound 3: the middle estimate sits 2.7-fold (0.42 log units) below what was measured; the range from low to high includes it.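

Going by these compounds alone, with the core held fixed, this is the first measured step at this position: in this assay, 2-(trifluoromethyl)pyridin-4-yl in place of 5-chloro-6-methoxypyridin-3-yl on the amide-type nitrogen gives a 3.3-fold higher number from compound 2 to compound 3 (0.52 log units; beyond the scatter). The group on this nitrogen can therefore move the read-out on its own. Nothing measured here gives a reason for the rise.

The trifluoromethyl group arrived as the chloro and methoxy groups left, so the step cannot be credited to any one of them. From the compounds shown here alone, how a pyridine carrying an amine would read on this nitrogen remains open.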